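Dropping the hydroxy from the side chain of compound 1

The source may hold more compounds than are shown below. What is called first, only, known or untested is meant among the compounds shown, and "the series" means these compounds.

Measured compounds:
compound 1, `OCCNc1nccc2c1ncn2C1O[C@H](CO)[C@@H](O)[C@H]1O`, 0%
compound 2, `[N-]=[N+]=Nc1[nH]ccc2ncnc1-2`, 20%
compound 3, `Nc1[nH]ccc2ncnc1-2`, 60%

In a functional assay (Homo sapiens) for inhibition of Nucleic Acid, tested at 100 uM (a higher number here means more inhibition at the concentration tested (going by the name of the read-out), a lower number less inhibition), compound 1 gives 0%, the lowest of the three numbers. Compound 2 stands nearest to it with 20%, a difference beyond the scatter, and compound 3 stands furthest with 60%. For the measured compounds named here, the one step between compounds differing in one place is a number 40 percentage points higher from compound 2 to compound 3 (beyond the scatter); it concerns the core itself and not the side chain.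

Compound 4, `CCNc1nccc2c1ncn2C1O[C@H](CO)[C@@H](O)[C@H]1O`, is the unmeasured compound. It differs from compound 1 in one place: hydrogen in place of hydroxy on a saturated chain carbon, two bonds along the chain from a nitrogen on an aromatic ring. Going by the values given here, no measured step touches this part of the molecule: the only step on record exchanges amino for azido on an aromatic carbon, which is unrelated to a hydroxy on a saturated chain. There is therefore no shown step to build an expectation of a shift on, and the expectation rests on compound 1 alone.

The account expects the step of a number 5 percentage points higher from compound 1 to compound 4 (within the scatter) to lie within the scatter. Compound 4 is estimated at 5%, with a range from -10% to 20%, because compound 1 gives 0% and the change leaves the core unchanged.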

Compound 4, a percentage reported as inhibition, at one concentration (the size of the read-out at that concentration, not a potency): 4%
For compound 4 the middle estimate is 1 percentage points above the measured one; low and high end bracket the measured number.
By their numbers in this assay, from the lowest: compounds 1 and 4 (each within the scatter of the next); then compound 2; then compound 3.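

In this assay, for the compounds shown here, the side chain is read for the first time, and hydrogen in place of hydroxy gives a number 4 percentage points higher from compound 1 to compound 4 (within the scatter), so the read-out does not separate the 2-hydroxyethyl chain from the ethyl chain on this core. Going by these compounds alone, the one earlier step, a number 40 percentage points higher from compound 2 to compound 3 (beyond the scatter), lay beyond the scatter but concerned a group on an aromatic carbon; this change, on a saturated chain carbon, two bonds along the chain from a nitrogen on an aromatic ring, shows that the hydroxy can go without a change that this assay can resolve. Nothing available offers an explanation for this result.

As far as these compounds go, what remains open is whether this position would stay as undemanding with another end group, such as a primary amine or a carboxylic acid, or with a longer chain such as propyl in place of ethyl. Compound 3 differs from compound 1 and from compound 4 in more than one place, so the compounds shown do not tell which part of the structure accounts for the distance between their numbers.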